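A few compounds are considered here, and "the series" means these few. Any claim that something is new, unique, unknown or untested is made for them only; others in the source may bear on it.

Compound 1, `Cc1cc2ccccc2nc1-c1cn(CCC(F)(F)C(F)(F)C(F)(F)C(F)(F)C(F)(F)C(F)(F)C(F)(F)C(F)(F)F)nn1`: in a functional assay on HeLa cells (Homo sapiens) for cytotoxicity, read by MTT assay, with a stated time of 24 h (a lower number here means a stronger inhibitor, a higher number a weaker inhibitor), compound 1 gives > 100 ug/mL, which is a limit of the assay and not a number.
Compound 2, `CCCCCCCCCCn1cc(-c2nc3ccccc3cc2CC)nn1`: in this assay compound 2 gives > 100 ug/mL, again a limit of the assay rather than a number.

Within the data shown here, compound 2 therefore stands at a limit in this assay: no number is known for it, and the one further value shown, that of compound 1, is a limit as well, so both sit at the same point, (the limit of > 100 ug/mL in this assay, at which 2 of the 2 values shown sit). Among the measured compounds shown here, no step between two measured compounds can be counted from this, and the two limits allow no order to be drawn between compound 1 and compound 2.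

Compound 3, `CCCCCCCCCCn1cc(-c2nc3ccccc3cc2CCCCC)nn1`, differs from compound 2 in one place: propyl in place of hydrogen on a saturated chain carbon, two bonds along the chain from an aromatic carbon. For the measured compounds named here, with both measured values resting at a limit, there is no measured step on which to found a direction, and a step in this assay from compound 2 to compound 3 beyond the usual scatter is not expected. Compound 3 is expected to give about 150 ug/mL in this assay, within a range from 60 ug/mL to 400 ug/mL, most likely reported once more as a limit. The step that the limit leaves unreadable from compound 2 to compound 3 that this estimate means is expected to lie within the scatter.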

Compound 3, half-maximal inhibitory concentration: > 100 ug/mL
Compound 3: only a limit was reported (the forecaster's own chance of this, stated with the estimate: 80%); the middle value does not contradict the limit.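

Compound 2 and compound 3 both stand at a limit in this assay, so no step can be read from compound 2 to compound 3: the limit of > 100 ug/mL in this assay, at which 3 of the 3 values shown sit.

The compounds shown leave open what number any of them would give in this assay, and whether propyl in place of hydrogen changes that number at all.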